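Tetraoxane Sulfonamides: From Chloropropyl to Methoxyphenyl on Sulfur

The compounds below may be only part of what the source reports. "The series", "measured", "known", "first", "only" and "open" are said of these compounds alone.

Measured so far:
- Compound 1, `CCS(=O)(=O)N1CCC2(CC1)OOC1(CCCCC1)OO2`. In a functional assay on Huh-7 cells (Homo sapiens) for cytotoxicity, read by MTT assay, with a stated time of 72 h (on this read-out lower numbers stand for higher toxicity in this test and higher numbers for lower toxicity in this test), compound 1 gives > 100 ug/mL, which is a limit of the test and not a number.
- Compound 2, `O=S(=O)(CCCCl)N1CCC2(CC1)OOC1(CCCCC1)OO2`. In this assay compound 2 gives > 100 ug/mL, again a limit of the test rather than a number.

Compound 2 therefore stands at the upper edge of what this assay reports, at the limit of > 100 ug/mL in this assay, at which 2 of the 2 values shown sit. Going by the values given here, the one measured step, a step that the two limits leave unreadable from compound 1 to compound 2, cannot be read in size, since both ends are limits. Compound 3, `COc1ccc(S(=O)(=O)N2CCC3(CC2)OOC2(CCCCC2)OO3)cc1`, differs from compound 2 in one place: 4-methoxyphenyl in place of 3-chloropropyl on a sulfonyl sulfur. Among the compounds with values here, no measured step touches a change of this kind, so the only guide is that both measured compounds sit at the limit. Compound 3 is expected to behave like them, with a step that the limit leaves unreadable from compound 2 to compound 3 that would not rise above the scatter. The estimate for compound 3 in this assay is 150 ug/mL, within a range from 60 ug/mL to 400 ug/mL, with a high chance that only a limit is reported once more.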

Compound 3, half-maximal cytotoxic concentration: > 100 ug/mL
Compound 3 was reported as a limit; the forecaster's own chance of this, stated with the estimate: 75%; the middle value lies beyond the limit too.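

In this assay compound 3 gives > 100 ug/mL, a limit of the test and not a number. Going by these compounds alone, no step among compound 1, compound 2 and compound 3 can be read in size, as all three sit at the same limit: the limit of > 100 ug/mL in this assay, at which 3 of the 3 values shown sit. The compounds shown leave open whether ethyl, 3-chloropropyl and 4-methoxyphenyl on the sulfonyl sulfur differ at all in this read-out.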